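Fluoro for Methyl on the Pyrrolidine-Bearing Analogue

This account rests on a few compounds, and the source may have more. Where it says the series, first, only, none or still open, it means among the compounds named here.

For the measured compounds named here, compound 2 `COc1cc2c(Oc3ccc(NC(=O)c4cc(-c5ccc(C)cc5)ccn4)cc3F)ccnc2cc1OCCCN1CCCC1` gives 440 nM in a functional assay on MKN-45 cells (Homo sapiens) for cytotoxicity, read by MTT assay, with a stated time of 72 h (on this read-out higher numbers stand for weaker inhibition and lower numbers for stronger inhibition), the lower of the two numbers known here. Compound 1 `COc1cc2c(Oc3ccc(NC(=O)c4cc(-c5ccc(F)cc5)ccn4)cc3F)ccnc2cc1OCCCN1CCCCC1` differs from compound 2 at two places, and in this assay compound 1 gives 1240 nM. Compound 3 `COc1cc2c(Oc3ccc(NC(=O)c4cc(-c5ccc(F)cc5)ccn4)cc3F)ccnc2cc1OCCCN1CCCC1` has not yet been measured; it differs from compound 2 by fluoro in place of methyl on an aromatic carbon. Going by the values given here, no single-change step between measured compounds is known, so the expectation leans on compound 1, which shares the fluoro group and gives 1240 nM. Compound 3 is expected to lose some potency by an estimated 1.8-fold higher number from compound 2 to compound 3 (0.26 log units; within the scatter). Compound 3 is estimated at 800 nM, within 350 nM to 1800 nM.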

Compound 3, half-maximal inhibitory concentration: 350 nM
Estimate against measurement, compound 3: 2.3-fold (0.36 log units) above; measured number inside the range.
By their numbers in this assay, from the lowest: compounds 3 and 2 (each within the scatter of the next); then compound 1.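

In this assay, 4-fluorophenyl and 4-methylphenyl cannot be told apart on the pyrrolidine-bearing compounds (a 1.3-fold lower number from compound 2 to compound 3 (0.10 log units; within the scatter)), so this aromatic carbon accepts either group. The first readable single change lies elsewhere: pyrrolidin-1-yl in place of piperidin-1-yl on the saturated chain carbon (a 3.5-fold lower number from compound 1 to compound 3 (0.55 log units; beyond the scatter)) makes a clear difference. Nothing available here explains either result. Still open, as far as these compounds go, is how a trifluoromethyl or methoxy group would read on that aromatic carbon, and how a morpholine would read in place of the pyrrolidine.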